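The source may report more compounds than this note shows. Statements on the series, on what has been measured and on what is new or still open speak of the compounds shown alone.

Compound 2 `CC(=O)N(Cc1cn(C(=O)c2ccccc2)nn1)[C@H]1CC(=O)[C@@H]2OC[C@H]1O2` carries a benzoyl group on an aromatic nitrogen. In a functional assay on MDA-MB-231 cells (Homo sapiens) for cytotoxicity, read by MTT assay, with a stated time of 48 h (on this read-out lower numbers stand for stronger inhibition and higher numbers for weaker inhibition), compound 2 gives > 50000 nM, which is a limit of the assay rather than a measured number. Compound 1 `CC(=O)N(Cc1cn(Cc2ccccc2)nn1)[C@H]1CC(=O)[C@@H]2OC[C@H]1O2` carries a benzyl group on that aromatic nitrogen instead. In this assay compound 1 gives > 50000 nM, again only a limit. The step that the two limits leave unreadable from compound 1 to compound 2 therefore cannot be sized, since the limit of > 50000 nM in this assay, at which 2 of the 2 values shown sit, holds both values. Compound 3 `CCCCCCCCn1cc(CN(C(C)=O)[C@H]2CC(=O)[C@@H]3OC[C@H]2O3)nn1` is not yet measured; it differs from compound 2 in that (octyl in place of benzoyl on an aromatic nitrogen). Among the measured compounds shown here, the only measured step touches the same aromatic nitrogen but has no readable size, so it offers no direction. Compound 3 is therefore expected to remain near the same limit, with an estimated value of 45000 nM in a range from 10000 nM to 150000 nM. This estimate means an expected step of an at least 1.1-fold lower number from compound 2 to compound 3 (0.04 log units; that floor lies within the scatter), with a real chance that only a limit is reported again.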

Compound 3, half-maximal inhibitory concentration: > 50000 nM
Compound 3 gave a limit, no number; the forecaster's own chance of this, stated with the estimate: 65%; at least 1.1-fold (0.04 log units) between middle value and limit.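

Among the compounds shown here, compound 3 also gives only a limit in this assay, so no step linking it to compound 1 or compound 2 can be read: the limit of > 50000 nM in this assay, at which 3 of the 3 values shown sit. The compounds shown leave open how benzyl, benzoyl and octyl on that aromatic nitrogen truly compare, and whether any group there gives a readable number.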